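Benzamido in place of the pyrazolylmethyl ether on the core

The source may hold more compounds than are shown below. What is called first, only, known or untested is meant among the compounds shown, and "the series" means these compounds.

Measured compounds in a functional assay on HEK293 cells for agonist activity at G-protein coupled receptor 39 (Homo sapiens), read by scintillation proximity assay and inositol phosphate accumulation, with a stated time of 75 min; on this read-out lower numbers stand for an effect already at smaller amounts and higher numbers for an effect only at larger amounts of compound:
compound 1 `Cc1nn(-c2ncnc3nc[nH]c23)c2c1C(OCc1ccc(C(C)C)cc1)CC(=O)N2`, 1690 nM
compound 2 `Cc1cc(C)n(CCOC2CC(=O)Nc3c2c(C)nn3-c2ncnc3nc[nH]c23)n1`, 2000 nM
compound 3 `Cc1cc(C)nc(-n2nc(C)c3c2NC(=O)CC3c2ccc(COc3cccc(Cl)c3)cc2)n1`, 3000 nM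

Compound 2 stands second highest of the three numbers. Its nearest neighbour is compound 1, a lower number, and its furthest is compound 3, a higher number; both gaps lie within the scatter, so the three values cannot be told apart.

Compound 4 `Cc1nn(-c2ncnc3nc[nH]c23)c2c1C(NC(=O)c1ccccc1)CC(=O)N2` is not yet measured. Against compound 2 the change is a group of 9 heavy atoms (7 carbon, 1 nitrogen, 1 oxygen; one six-membered aromatic ring of carbon only) in place of a group of 10 heavy atoms (7 carbon, 2 nitrogen, 1 oxygen; one five-membered aromatic ring with 2 hetero atoms), on a saturated ring carbon.

Among the compounds with values here, only one measured step exists, a 1.2-fold higher number from compound 1 to compound 2 (0.07 log units; within the scatter). Within the data shown here, that step exchanges groups on the chain carbon bound to the oxygen while keeping the oxygen link to the core; the move to compound 4 removes the whole oxygen-bearing side group and places benzamido directly on the saturated ring carbon, so no measured step covers it. Among the measured compounds shown here, every value so far sits within the scatter of the others, which gives no direction for the new group. The expected step is therefore none beyond the scatter, no change at the digits printed from compound 2 to compound 4 (within the scatter), with a wide range. For compound 4 the estimate in this assay is 2000 nM, between 600 nM and 7000 nM.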

Compound 4, half-maximal effective concentration: 158 nM
Estimate against measurement, compound 4: 13-fold (1.10 log units) above; measured number outside the range, below it.
By their numbers in this assay, from the lowest: compound 4; then compounds 1, 2 and 3 (each within the scatter of the next).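

In this assay, within the data shown here, the saturated ring carbon, three ring bonds from the ring nitrogen, proves sensitive to its substituent, which the earlier compounds, all within the scatter of one another, did not show: benzamido in place of the pyrazole-bearing ether side group gives a 13-fold lower number from compound 2 to compound 4 (1.10 log units; beyond the scatter) and sets compound 4 apart from the rest. This single step changes the link to the core, the ring type and the hydrogen-bond donor count (1 entering, 0 leaving) together, so it credits none of these alone. Nothing available bears on the reason for the step.

Still open, going by these compounds, is whether the amide link or the phenyl ring carries the step, which a plain acetamido or a free amine on this carbon would separate. Also open, on these data alone, is how far the phenyl ring tolerates additions, such as a chlorine or a methoxy group.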